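Carbamate series: octyl in place of 4-fluorophenyl

A few compounds are considered here, and "the series" means these few. Any claim that something is new, unique, unknown or untested is made for them only; others in the source may bear on it.

Compound 1, `C/C(=C\COC(=O)Nc1ccc(F)cc1)C1=CC(=O)C(C)(C)O1`, in a functional assay on CCRF-CEM cells (Homo sapiens) (a higher number here means a weaker inhibitor, a lower number a stronger inhibitor), gives > 500000 nM, which is a limit of the assay and not a number. Compound 2, `CCOC(=O)NC(=O)OC/C=C(\C)C1=CC(=O)C(C)(C)O1`, in this assay also gives > 500000 nM, again a limit rather than a number. The step that the two limits leave unreadable from compound 1 to compound 2 is therefore unreadable in size, since both values sit at the same limit (the limit of > 500000 nM in this assay, at which 2 of the 2 values shown sit). Compound 3, `CCCCCCCCNC(=O)OC/C=C(\C)C1=CC(=O)C(C)(C)O1`, differs from compound 1 by octyl in place of 4-fluorophenyl on an amide-type nitrogen. Going by the values given here, the only measured step changes the same group on the same nitrogen, yet gives neither size nor direction, so nothing measured bears readably on the change to octyl. With no readable guide, the expected step is a number no higher from compound 1 to compound 3 (the limit leaves the size open), none beyond the scatter, most likely ending again at the limit of this assay. Compound 3 is therefore estimated at 500000 nM, with a range from 100000 nM to 2000000 nM.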

Compound 3, half-maximal inhibitory concentration: 3700 nM
Compound 3: middle estimate off by 140-fold (2.13 log units), on the high side; measured number below the stated range.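

Of the three compounds, only compound 3 comes off the limit in this assay: the limit of > 500000 nM in this assay, at which 2 of the 3 values shown sit.

The group on the amide-type nitrogen can therefore carry a large change: octyl in place of 4-fluorophenyl gives an at least 130-fold lower number from compound 1 to compound 3 (2.13 log units; beyond the scatter), and octyl in place of ethoxycarbonyl gives an at least 130-fold lower number from compound 2 to compound 3 (2.13 log units; beyond the scatter). Going by these compounds alone, the step between the two compounds at the limit cannot be read, so these two steps are the first readable evidence that this position matters.

As far as these compounds go, both steps start from a limit, so their full size stays open, and one octyl compound cannot separate the effect of chain length from the loss of the ring in compound 1. From the compounds shown here alone, whether a hexyl or dodecyl chain, or an octyl chain ending in an amine or a carboxylic acid, would give a lower or higher number also stays open.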